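The source may hold more compounds than are shown below. What is called first, only, known or untested is meant among the compounds shown, and "the series" means these compounds.

compound 1 `C=C(Br)C(=O)Nc1ccc(C(=O)/C=C/c2ccc(OC)c(OC)c2)cc1`: 1600 nM
compound 2 `C=C(Br)C(=O)Nc1ccc(C(=O)/C=C/c2ccc(OC)cc2OC)cc1`: 1100 nM

In an ADME assay on CCRF-CEM cells (Homo sapiens) for antiproliferative activity, with a stated time of 48 h (on this read-out lower numbers stand for stronger inhibition and higher numbers for weaker inhibition), compound 2 at 1100 nM and compound 1 at 1600 nM lie within the usual scatter of each other. Compound 3 `C=C(Br)C(=O)Nc1ccc(C(=O)/C=C/c2ccc(OC)c(OC)c2OC)cc1` carries methoxy in place of hydrogen on an aromatic carbon relative to compound 2, that is, methoxy in place of hydrogen on an aromatic carbon. Among the compounds with values here, no measured pair shows this change, so the only guide is how close compound 2 at 1100 nM and compound 1 at 1600 nM stand, and no step beyond the scatter is expected in this assay for this addition. The expected change is a 1.1-fold lower number from compound 2 to compound 3 (0.04 log units; within the scatter) and stays small. Compound 3 is estimated at 1000 nM, with an expected range of 400 nM to 2500 nM.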

Compound 3, half-maximal inhibitory concentration: 840 nM
Compound 3: middle estimate off by 1.2-fold (0.08 log units), on the high side; the range from low to high includes it.
By their numbers in this assay, from the lowest: compounds 3, 2 and 1 (each within the scatter of the next).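

In this assay the added methoxy group, ortho to two methoxy groups, gives a 1.3-fold lower number from compound 2 to compound 3 (0.12 log units; within the scatter) and a 1.9-fold lower number from compound 1 to compound 3 (0.28 log units; within the scatter) and so no step beyond the scatter. This position therefore takes a third methoxy group without a clear change in the read-out, whichever of the two earlier compounds serves as the comparison. Nothing available explains this result. As far as these compounds go, whether a different group at this position, such as an amine or a carboxylic acid, would give a step beyond the scatter stays open.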